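Predicting Clearance After One Substituent Exchange

A few compounds are considered here, and "the series" means these few. Any claim that something is new, unique, unknown or untested is made for them only; others in the source may bear on it.

Of the compounds shown here, three have been measured so far: compound 1 `COCCc1nc2nc(C)cc(Nc3ccc(S(F)(F)(F)(F)F)cc3)n2n1`, compound 2 `CSc1nc2nc(C)cc(Nc3ccc(S(F)(F)(F)(F)F)cc3)n2n1` and compound 3 `CSc1nc2nc(C)cc(Nc3ccc(C(F)(F)F)cc3)n2n1`, all in an in vitro ADME assay on microsomes from liver (Homo sapiens) for metabolic stability; a lower number here means slower removal, a higher number faster removal of the compound. In this assay compound 1 gives 11.5 mL.min-1.g-1, compound 2 gives 22.4 mL.min-1.g-1 and compound 3 gives 18.7 mL.min-1.g-1. Compound 2 and compound 1 differ in a single place, (2-methoxyethyl in place of methylsulfanyl on an aromatic carbon), and this gave a 1.9-fold lower number from compound 2 to compound 1 (0.29 log units; within the scatter). Compound 2 and compound 3 differ in their cores, (a group of 4 heavy atoms (1 carbon, 3 fluorine; no ring) in place of a group of 6 heavy atoms (5 fluorine, 1 sulfur; no ring), on an aromatic carbon), which gave a 1.2-fold lower number from compound 2 to compound 3 (0.08 log units; within the scatter). Compound 4 `COCCc1nc2nc(C)cc(Nc3ccc(C(F)(F)F)cc3)n2n1` has not yet been measured. Relative to compound 3 it carries 2-methoxyethyl in place of methylsulfanyl on an aromatic carbon, and since the place is described in the same words as for the step from compound 2 to compound 1, this is the same change, made here on the core of compound 3. Going by the values given here, for compound 4 a step of a 1.9-fold lower number from compound 3 to compound 4 (0.27 log units; within the scatter) is expected in this assay, alongside the earlier step, because a 1.9-fold lower number from compound 2 to compound 1 (0.29 log units; within the scatter) is the only measured example of this change. Compound 4 is therefore estimated at 10 mL.min-1.g-1. For compound 4 the expected range runs from 5 mL.min-1.g-1 to 20 mL.min-1.g-1.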

Compound 4, intrinsic clearance in microsomes in the Homo sapiens assay: 9 mL.min-1.g-1
Compound 4: middle estimate off by 1.1-fold (0.05 log units), on the high side, and the stated range covers the measured number.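

In the Homo sapiens assay, 2-methoxyethyl in place of methylsulfanyl gave a 2.1-fold lower number from compound 3 to compound 4 (0.32 log units; beyond the scatter), and the change carried from one core to the other with no visible difference in size: the same change on two cores in the Homo sapiens assay, a 1.9-fold lower number (0.29 log units; within the scatter) from compound 2 to compound 1 and a 2.1-fold lower number (0.32 log units; beyond the scatter) from compound 3 to compound 4, 1.1-fold (0.03 log units) apart, within the scatter of two such steps
The other exchange, a group of 4 heavy atoms in place of a group of 6 heavy atoms on an aromatic carbon, gave a 1.3-fold lower number from compound 1 to compound 4 (0.11 log units; within the scatter), and it too looks the same on both cores: the same change on two cores in the Homo sapiens assay, a 1.2-fold lower number (0.08 log units; within the scatter) from compound 2 to compound 3 and a 1.3-fold lower number (0.11 log units; within the scatter) from compound 1 to compound 4, 1.1-fold (0.03 log units) apart, within the scatter of two such steps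
In a physicochemical assay for lipophilicity, at pH 7.4 (a higher number here means a more lipophilic compound, a lower number a more polar compound), compound 3 gives 3.2 and compound 4 gives 2.7, so the methylsulfanyl exchange also came with a lower number, but two cores do not make a rule for the series, and a single pair does not show that lipophilicity and clearance are linked: the measured distribution coefficient of compound 3, 3.2, and of compound 4, 2.7, a number 0.50 log units lower (beyond the scatter)

The compounds shown leave open how an amine or a longer chain would behave in that same place on the five-membered aromatic ring. They also leave open whether the step would hold on a third core, for instance one carrying a nitrile in place of trifluoromethyl.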